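The source may hold more compounds than are shown below. What is called first, only, known or untested is meant among the compounds shown, and "the series" means these compounds.

Compound 1, `CC(C)[C@@H]1CC[C@@H](C)C[C@@]12N(C)C(=O)[C@@H]1[C@H]3C(=O)N(C)C(=O)[C@H]3ON12`, has been tested in a functional assay, read by spectrophotometry, with a stated time of 2 h, tested at 2 mg/mL (a higher number here means a stronger effect of the compound at the concentration tested, a lower number a weaker effect), where compound 1 gives 49.7%. Within the data shown here, of the two numbers measured so far this is the top one, but only nominally: compound 2, `CC(C)[C@@H]1CC[C@@H](C)C[C@@]12N(C)C(=O)[C@@H]1[C@H]3C(=O)N(c4ccccc4)C(=O)[C@H]3ON12`, sits within the scatter of it. In this assay compound 2 gives 48.2%, and the step of a number 1.5 percentage points lower from compound 1 to compound 2 (within the scatter) came with phenyl in place of methyl on an amide-type nitrogen in a ring, a change that left the read-out effectively unchanged.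

Compound 3, `Cc1cccc(N2C(=O)[C@H]3[C@H](ON4[C@@H]3C(=O)N(C)[C@@]43C[C@H](C)CC[C@H]3C(C)C)C2=O)c1`, has not yet been measured in this assay. Its difference from compound 1 is 3-methylphenyl in place of methyl on an amide-type nitrogen in a ring. Among the measured compounds shown here, the one measured step that bears on this is the one from compound 1 to compound 2, because a number 1.5 percentage points lower from compound 1 to compound 2 (within the scatter) shows that putting an aromatic ring onto this same nitrogen did not move the read-out beyond the scatter. A 3-methylphenyl group at the same place is therefore expected to behave alike, and no step beyond the scatter is expected in this assay.

Compound 3 is accordingly estimated at 48% in this assay, with a range from 38% to 58%, which means an expected step of a number 1.7 percentage points lower from compound 1 to compound 3 (within the scatter) within the scatter.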

Compound 3, a percentage reported as activity, at one concentration (the size of the read-out at that concentration, not a potency): 43.6%
Compound 3: middle estimate off by 4.4 percentage points, on the high side; the measured number falls inside the stated range.
By their numbers in this assay, from the lowest: compounds 3, 2 and 1 (each within the scatter of the next).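

With 3-methylphenyl in place of methyl on an amide-type nitrogen in a ring, this assay shows a number 6.1 percentage points lower from compound 1 to compound 3 (within the scatter) and so extends the earlier finding from an unsubstituted phenyl to a substituted one: all three groups seen at this nitrogen give numbers that cannot be told apart from their nearest neighbours. The new compound also adds a change the earlier pair could not show, methyl in place of hydrogen on an aromatic carbon, which gives a number 4.6 percentage points lower from compound 2 to compound 3 (within the scatter) and therefore offers no sign that this extra methyl alters the read-out. No measurement is available that could account for these numbers.

The compounds shown leave open whether any other group on this nitrogen, such as a longer alkyl chain, or a phenyl ring carrying a carboxylic acid or an amine, would move the read-out beyond the scatter. They also leave open whether a methyl at another carbon of the aromatic ring would behave like this one, and, since each number comes from a single concentration, whether these compounds differ in potency.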